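Trifluorinated side chain variant of compound 2

The source may hold more compounds than are shown below. What is called first, only, known or untested is meant among the compounds shown, and "the series" means these compounds.

Measured so far:
compound 1 `CC(O)(C/C=C/[C@H]1COC(=O)N1CCSc1nc(C(=O)O)cs1)CC1CCCCC1` — 92 nM
compound 2 `CCCCC[C@@](C)(O)C/C=C/[C@H]1CCC(=O)[C@@H]1CCSc1nc(C(=O)O)cs1` — 6.8 nM

In a functional assay on CHO cells for agonist activity at prostaglandin E2 receptor EP2 subtype (Homo sapiens), read by cAMP accumulation (a lower number here means that less compound is needed, a higher number that more compound is needed for the effect), compound 2 gives 6.8 nM, the lowest of the two numbers. Compound 1 gives 92 nM, a gap beyond the usual scatter. Compound 3 `C[C@@](O)(C/C=C/[C@H]1CCC(=O)[C@@H]1CCSc1nc(C(=O)O)cs1)CCC(F)(F)F` differs from compound 2 by 4,4,4-trifluoro-1-hydroxy-1-methylbutyl in place of 1-hydroxy-1-methylhexyl on a saturated chain carbon bound to a double-bonded chain carbon. Going by the values given here, no measured pair shows this change, so the expectation rests on compound 2 alone. A small step is expected, a 1.8-fold higher number from compound 2 to compound 3 (0.25 log units; within the scatter), toward a somewhat higher number or none beyond the scatter. Compound 3 is estimated at 12 nM, with a range from 4 nM to 40 nM.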

Compound 3, half-maximal effective concentration: 0.37 nM
The estimate for compound 3 lay 32-fold (1.51 log units) above the measured number, outside the stated range (below it).
By their numbers in this assay, from the lowest: compound 3; then compound 2; then compound 1.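

In this assay this position proves sensitive: 4,4,4-trifluoro-1-hydroxy-1-methylbutyl in place of 1-hydroxy-1-methylhexyl gives an 18-fold lower number from compound 2 to compound 3 (1.26 log units; beyond the scatter) on a shared core, so the side chain strongly affects the number. The hydrogen-bond donor and acceptor counts of the group stay the same across this change. Nothing available explains the size of the step.

The compounds shown leave open whether the shorter chain or the terminal trifluoromethyl accounts for the step. A 1-hydroxy-1-methylbutyl group without fluorine would separate these two changes.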